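From Propyl to Butyl: A Step Still Unmeasured

The source may report more compounds than this note shows. Statements on the series, on what has been measured and on what is new or still open speak of the compounds shown alone.

Among the measured compounds shown here, in an ADME assay on HaCaT cells (Homo sapiens) for cytotoxicity, read by MTT assay, with a stated time of 48 h (a higher number here means that more compound is needed for the effect, a lower number that less compound is needed), compound 2 `CCCOC(=O)[C@@H](N)CCC(=O)NCCSC(C)=O` gives 548000 nM, the higher of the two numbers known so far. For the measured compounds named here, the only other measured compound, compound 1 `CCCCOC(=O)[C@@H](N)CCC(=O)NCCSC(=O)c1ccccc1`, gives 97000 nM, a lower number by a margin beyond the usual scatter. Compound 3 `CCCCOC(=O)[C@@H](N)CCC(=O)NCCSC(C)=O` awaits measurement. It differs from compound 2 by one change, (methyl in place of hydrogen on a saturated chain carbon, three bonds along the chain from an oxygen next to a carbonyl group), which turns propyl into butyl. Going by the values given here, no measured pair isolates this change. Compound 1 also carries butyl, but it differs from compound 3 in a second place, so compound 1 with 97000 nM offers only a weak hint towards lower numbers. A small step in that direction is expected, probably within the scatter, and the estimated step is a 1.7-fold lower number from compound 2 to compound 3 (0.23 log units; within the scatter). For compound 3 the estimated value is 320000 nM, with an expected range from 140000 nM to 620000 nM.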

Compound 3, half-maximal effective concentration: 563000 nM
For compound 3 the middle estimate is 1.8-fold (0.25 log units) below the measured one, within the range that was stated.
By their numbers in this assay, from the lowest: compound 1; then compounds 2 and 3 (each within the scatter of the next).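

In this assay the change from propyl to butyl now has a measured pair, and a 1.0-fold higher number from compound 2 to compound 3 (0.01 log units; within the scatter) shows that methyl in place of hydrogen at this chain carbon makes no difference beyond the scatter. Among the compounds shown here, with butyl held constant, the change of methyl in place of phenyl on a carbonyl carbon gives a 5.8-fold higher number from compound 1 to compound 3 (0.76 log units; beyond the scatter) and lies beyond the scatter, so among the single changes read here only this one separates two compounds. Nothing available explains either result.

On these data alone, it remains open whether a longer chain, such as pentyl, or a branched chain at the same place would also stay within the scatter. As far as these compounds go, it is equally open whether propyl and butyl would match when phenyl sits on the carbonyl carbon, or how an amine or a carboxylic acid would fare there.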